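Methylamino in Place of Methyl on Compound 3

This account rests on a few compounds, and the source may have more. Where it says the series, first, only, none or still open, it means among the compounds named here.

Measured so far, in an assay on cells for inhibition of cytochrome P450 11B2, mitochondrial (Homo sapiens), read by HPLC, with a stated time of 90 min; a lower number here means a stronger inhibitor, a higher number a weaker inhibitor:
compound 1, `Fc1ccc2nc(-n3ccnn3)n(C3CC3)c2c1`: 1060 nM
compound 2, `Fc1ccc2nc(-c3cnco3)n(C3CC3)c2c1`: a limit, > 10000 nM
compound 3, `Cc1ncncc1-c1nc2cc(F)c(F)cc2n1C1CC1`: 17 nM

Compound 3 gives the lowest number shown; compound 1 gives the nearest measured number, well beyond the scatter away. For compound 2 only a limit is known, at the limit of > 10000 nM in this assay, at which 1 of the 3 values shown sits. Among the compounds with values here, the one measured step, an at least 9.4-fold higher number from compound 1 to compound 2 (0.97 log units; beyond the scatter), exchanges one five-membered ring for another and says nothing directly about the change now considered.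

Compound 4, `CNc1ncncc1-c1nc2cc(F)c(F)cc2n1C1CC1`, differs from compound 3 by methylamino in place of methyl on an aromatic carbon. Within the data shown here, no measured step bears on this substitution, so its effect in this assay is an open guess. A step within the scatter or a small shift either way is expected, a 1.8-fold higher number from compound 3 to compound 4 (0.25 log units; within the scatter). Compound 4 is therefore estimated at 30 nM, between 7 nM and 130 nM.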

Compound 4, half-maximal inhibitory concentration: < 2 nM
Compound 4: no number, only a limit; the forecaster's own chance of this, stated with the estimate: 2%; middle value at least 15-fold (1.17 log units) away from the limit.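

In this assay, methylamino in place of methyl on this aromatic carbon, next to the ring nitrogen, gives an at least 8.5-fold lower number from compound 3 to compound 4 (0.92 log units; beyond the scatter). What this position carries therefore matters, which the earlier step, an exchange of one five-membered ring for another, could not show. For compound 4 the value < 2 nM is a limit of the assay, not a number.

The change adds a nitrogen, a hydrogen-bond donor and a hydrogen-bond acceptor together, and the compounds shown do not separate these. On these data alone, whether a plain amino group, dimethylamino or a longer chain such as ethylamino would behave alike stays open.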